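A few compounds are considered here, and "the series" means these few. Any claim that something is new, unique, unknown or untested is made for them only; others in the source may bear on it.

Measured so far:
compound 1 `O=C(CN1CCN(c2ccccn2)CC1)Nc1cccnc1` — 25800 nM
compound 2 `Cc1cccc(NC(=O)CN2CCC(c3ccccc3)CC2)c1` — 135 nM

Of the compounds shown here, two have been measured in an assay on cells for antagonist activity at D(4) dopamine receptor (Homo sapiens), read by luminescence and beta-arrestin recruitment, with a stated time of 90 min; a lower number here means a stronger inhibitor, a higher number a weaker inhibitor. Compound 1 gives 25800 nM, the higher of the two numbers, while compound 2 gives 135 nM, a difference well beyond the scatter. Compound 3 `Cc1cccc(NC(=O)CN2CCN(c3ccccn3)CC2)c1` has not yet been measured. It differs from compound 1 in one place: 3-methylphenyl in place of pyridin-3-yl on an amide-type nitrogen. For the measured compounds named here, compound 3 thus carries the same 3-methylphenyl amide as compound 2, while the rest of its structure matches compound 1, so no measured pair isolates this single change. The step from compound 1 to compound 3 is expected to lower the number beyond the scatter, with a size estimated at a 10-fold lower number from compound 1 to compound 3 (1.01 log units; beyond the scatter). This expectation rests on compound 2, which gives 135 nM in this assay with the same amide substituent. For compound 3 the expected value is 2500 nM, with a range from 500 nM to 12000 nM.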

Compound 3, half-maximal inhibitory concentration: 313 nM
Compound 3: middle estimate off by 8.0-fold (0.90 log units), on the high side; the measured number lies below the stated range.
By their numbers in this assay, from the lowest: compound 2; then compound 3; then compound 1.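

In this assay, putting 3-methylphenyl in place of pyridin-3-yl on an amide-type nitrogen gives an 82-fold lower number from compound 1 to compound 3 (1.92 log units; beyond the scatter). For the compounds shown here, this pair is the first to isolate the position, and it shows that this single exchange, with the rest of compound 1 kept, is enough to produce a large step. No measured data shown here explain the size of this step.

Going by these compounds alone, the exchange swaps a ring with one hetero atom for a carbon-only ring and also adds a methyl group, so the single pair cannot separate these two parts of the change. An unsubstituted phenyl group on the same nitrogen would divide the step between them, and a 3-chlorophenyl or 3-methoxyphenyl group would show whether the methyl group itself can be replaced.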